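Swapping the aryl group for an arylamino group

This account rests on a few compounds, and the source may have more. Where it says the series, first, only, none or still open, it means among the compounds named here.

In a functional assay on Jurkat cells (Homo sapiens) for antiproliferative activity, read by MTT assay, with a stated time of 72 h (on this read-out higher numbers stand for weaker inhibition and lower numbers for stronger inhibition), compound 1 `COc1cc(C(=O)c2sc3ccccc3c2-c2ccc(F)cc2)cc(OC)c1OC` gives 2300 nM. Compound 2 `COc1ccc(-c2c(C(=O)c3cc(OC)c(OC)c(OC)c3)sc3ccccc23)cc1C` carries 4-methoxy-3-methylphenyl in place of the 4-fluorophenyl of compound 1. In this assay compound 2 reaches only > 10000 nM, which is a limit of the assay and not a number, as noted by the limit of > 10000 nM in this assay, at which 1 of the 2 values shown sits. On these data alone, the step of an at least 4.3-fold higher number from compound 1 to compound 2 (0.63 log units; beyond the scatter) therefore shows that this change weakens inhibition beyond the scatter, though its full size stays open. Compound 3 `CCOc1ccc(Nc2c(C(=O)c3cc(OC)c(OC)c(OC)c3)sc3ccccc23)cc1` has not yet been measured. It differs from compound 2 by (4-ethoxyphenyl)amino in place of 4-methoxy-3-methylphenyl on an aromatic carbon. For the measured compounds named here, no measured step involves an arylamino group at this place, so the only guide is that compound 1 has a number while compound 2 sits at the limit. Compound 3 is expected to land near 3000 nM, between 500 nM and 20000 nM. The expected step of an at least 3.3-fold lower number from compound 2 to compound 3 (0.52 log units; beyond the scatter) cannot be judged firmly against a limit.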

Compound 3, half-maximal inhibitory concentration: 300 nM
Estimate against measurement, compound 3: 10-fold (1.00 log units) above, outside the stated range (below it).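

In this assay, for the compounds shown here, the (4-ethoxyphenyl)amino group at this place gives a 7.7-fold lower number from compound 1 to compound 3 (0.88 log units; beyond the scatter), so a group here can improve on 4-fluorophenyl, whereas the only earlier change at this place weakened inhibition. Replacing 4-methoxy-3-methylphenyl with the same group gives an at least 33-fold lower number from compound 2 to compound 3 (1.52 log units; beyond the scatter), showing that the choice of group at this place can shift the result by a large amount. Compound 2 stands at a limit and not at a number, so the full size of that step stays open: the limit of > 10000 nM in this assay, at which 1 of the 3 values shown sits.

The compounds shown leave open whether the gain belongs to the amino nitrogen or to the ethoxy group, as the two enter together in a single change. On these data alone, it also stays open how a (4-fluorophenyl)amino group, or a 4-ethoxyphenyl group joined directly to the ring, would compare.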